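Cytotoxicity notes: fluoroquinoline pyrazoles, the next analogue

The source may hold more compounds than are shown below. What is called first, only, known or untested is meant among the compounds shown, and "the series" means these compounds.

Measured in an ADME assay on Huh-7 cells (Homo sapiens) for cytotoxicity, read by XTT assay, with a stated time of 3 days, tested at 200 uM; a higher number here means a weaker effect of the compound at the concentration tested, a lower number a stronger effect:
- compound 1, `COc1ccc(-c2cc(-c3ccc4cc(F)ccc4n3)n(-c3ccc(OC)cc3)n2)cc1`: 98.4%
- compound 2, `NS(=O)(=O)c1ccc(-n2nc(-c3ccccc3)cc2-c2ccc3cc(F)ccc3n2)cc1`: 83.6%

Of the compounds shown here, two of the shared core carry a value so far. In this assay compound 1 gives 98.4%, a reading at the upper end of the scale. In this assay compound 2 gives 83.6%, the lowest of the two numbers; its nearest neighbour is compound 1, a number higher by more than the usual scatter. Among the compounds with values here, no single-site step between measured compounds is known, so the gap between compound 1 and compound 2 cannot be assigned to one change: both the group on the pyrazole nitrogen and the group on the carbon-bound phenyl differ.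

The next analogue is compound 3, `COc1ccc(-c2cc(-c3ccc4cc(F)ccc4n3)n(-c3ccc(S(N)(=O)=O)cc3)n2)cc1`. Relative to compound 2 it differs by methoxy in place of hydrogen on an aromatic carbon. The entering group is methoxy, placed on an aromatic carbon of a six-membered aromatic ring of carbon only, para to a large group; cut one bond further out the change reads phenyl to 4-methoxyphenyl.

What to expect: compound 1 carries methoxy at the same ring and sits high, at 98.4%, but it also differs from compound 2 elsewhere, so that number is only a loose guide. The step from compound 2 to compound 3 is expected to be small and upward, a number 6.4 percentage points higher from compound 2 to compound 3 (within the scatter), within the scatter. For compound 3 in this assay the estimated value is 90%, with a range from 76% to 100%.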

Compound 3, a percentage reported as activity, at one concentration (the size of the read-out at that concentration, not a potency): 89.5%
Compound 3: middle estimate off by 0.5 percentage points, on the high side; measured number inside the range.
By their numbers in this assay, from the lowest: compounds 2, 3 and 1 (each within the scatter of the next, the first and the last beyond it).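

Compound 3 gives the series its first single-site readings: phenyl to 4-methoxyphenyl in this assay is a number 5.9 percentage points higher from compound 2 to compound 3 (within the scatter), so methoxy in place of hydrogen at this position does not move the number beyond the scatter. The second step, with sulfamoyl in place of methoxy on an aromatic carbon, is a number 8.9 percentage points lower from compound 1 to compound 3 (within the scatter), and it too stays within the scatter, so neither change taken alone shows a clear effect on the read-out at the tested concentration. No independent measurement bears on these readings.

As far as these compounds go, whether this position tolerates other groups remains open: an amine, a carboxylic acid or a longer chain such as butoxy in place of methoxy could still give a step beyond the scatter, and the same holds for a carboxylic acid or a methyl group in place of sulfamoyl. Each reading also comes from one concentration, so these compounds give no potency and do not show how any of them would behave at higher exposure or in other cell types.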